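Chain length in nitroimidazole-bearing anilinoquinazolines: cytotoxicity notes

The source may report more compounds than this note shows. Statements on the series, on what has been measured and on what is new or still open speak of the compounds shown alone.

Measured in a functional assay on HT-29 cells (Homo sapiens) for cytotoxicity, read by sulforhodamine B assay, with a stated time of 72 h; on this read-out lower numbers stand for stronger inhibition and higher numbers for weaker inhibition:
Compound 1: `COc1cc2ncnc(Nc3ccc(F)c(Cl)c3)c2cc1OCCn1ccnc1[N+](=O)[O-]`, 10000 nM
Compound 2: `COc1cc2ncnc(Nc3ccc(F)c(Cl)c3)c2cc1OCCCCn1ccnc1[N+](=O)[O-]`, 1620 nM
Compound 3: `C#Cc1cccc(Nc2ncnc3cc(OC)c(OCCCCn4ccnc4[N+](=O)[O-])cc23)c1`, 6900 nM

One change occurs twice in the set: 2-(2-nitro-1H-imidazol-1-yl)ethyl in place of 2-nitro-1H-imidazol-1-yl on a saturated chain carbon, two bonds along the chain from an oxygen on an aromatic ring. Within the measured compounds it gives a 6.2-fold lower number from compound 1 to compound 2 (0.79 log units; beyond the scatter). Compound 3 carries a different aryl amine on the shared core; the difference between the core of compound 1 and the core of compound 3 is not broken down here. On the four-carbon chain, the measured step is a 4.3-fold higher number from compound 2 to compound 3 (0.63 log units; beyond the scatter).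

Compound 4 `C#Cc1cccc(Nc2ncnc3cc(OC)c(OCCCCCCn4ccnc4[N+](=O)[O-])cc23)c1` is not yet measured. It differs from compound 3 by 2-(2-nitro-1H-imidazol-1-yl)ethyl in place of 2-nitro-1H-imidazol-1-yl on a saturated chain carbon, four bonds along the chain from an oxygen on an aromatic ring. For the measured compounds named here, this is the same kind of change as the one from compound 1 to compound 2, but not the same: the place is four bonds along the chain from an oxygen on an aromatic ring rather than two bonds along the chain from an oxygen on an aromatic ring, and the chain being extended is already the longer one.

Going by the values given here, because the only measured instance of this kind of change gave a 6.2-fold lower number from compound 1 to compound 2 (0.79 log units; beyond the scatter), a lowering is expected for compound 4 as well. A single instance on a shorter chain is a thin basis, so a smaller step is assumed; the expected step for compound 4 is a 2.8-fold lower number from compound 3 to compound 4 (0.44 log units; beyond the scatter). Compound 4 is estimated at 2500 nM in this assay, with a range from 800 nM to 7000 nM.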

Compound 4, half-maximal inhibitory concentration: 3460 nM
The estimate for compound 4 lay 1.4-fold (0.14 log units) below the measured number; the range from low to high includes it.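

In this assay, the change on the core of compound 3 gives a 2.0-fold lower number from compound 3 to compound 4 (0.30 log units; within the scatter), so this step alone cannot be told from repeat scatter. The change does not carry over at one size between the two cores: the same change on two cores in this assay, a 6.2-fold lower number (0.79 log units; beyond the scatter) from compound 1 to compound 2 and a 2.0-fold lower number (0.30 log units; within the scatter) from compound 3 to compound 4, 3.1-fold (0.49 log units) apart, beyond the scatter of two such steps

This does not show that the core alone sets the size of the step, since the two instances also differ in place, two bonds along the chain from an oxygen on an aromatic ring in one and four bonds along the chain in the other. With only two instances, the comparison gives no general rule for the series.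

On these data alone, what stays open is how much of the gap belongs to the core and how much to the place on the chain; a 2-(2-nitro-1H-imidazol-1-yl)ethyl chain on the core of compound 3 would give a step at the same place as the first one. Also open, as far as these compounds go, is how the number in this assay responds to a still longer chain, or to an amine in place of the 2-nitro-1H-imidazol-1-yl group.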